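The compounds below may be only part of what the source reports. "The series", "measured", "known", "first", "only" and "open" are said of these compounds alone.

Compound 1 `CC1CCC(=O)N1CC#CCn1ccnc1` gives > 100 mg/kg in a functional assay on the whole organism for agonist activity, with Mus musculus as the target (a lower number here means that less compound is needed, a higher number that more compound is needed for the effect), which is a limit of the assay and not a number. Compound 2 `CC1CCC(=O)N1CC#CCN(C)C` gives 1.7 mg/kg and compound 3 `CC(=O)N(C)CC#CCN(C)C` gives 0.97 mg/kg, two values within the scatter of each other. Compound 4 `COC(=O)N(C)CC#CCN(C)C` differs from compound 3 by methoxy in place of methyl on a carbonyl carbon. Among the compounds with values here, the only measured step, an at least 58-fold lower number from compound 1 to compound 2 (1.76 log units; beyond the scatter), is large, but it lies on a saturated chain carbon bound to a triple-bonded carbon, so it does not bear directly on this change. Compound 2 at 1.7 mg/kg and compound 3 at 0.97 mg/kg differ around the carbonyl yet stay within the scatter, so only a small change is expected. The expected step is a 1.5-fold higher number from compound 3 to compound 4 (0.19 log units; within the scatter), not beyond the scatter. The estimate for compound 4 is 1.5 mg/kg, with an expected range of 0.4 mg/kg to 6 mg/kg.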

Compound 4, dose for half-maximal effect: 17.3 mg/kg
For compound 4 the middle estimate is 12-fold (1.06 log units) below the measured one; measured number above the stated range.
By their numbers in this assay, from the lowest: compounds 3 and 2 (each within the scatter of the next); then compound 4. At a limit, above all of these: compound 1.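

Within the data shown here, at the carbonyl carbon whose other neighbour is the amide-type nitrogen, this assay proves sensitive to this exchange: acetyl to methoxycarbonyl gives an 18-fold higher number from compound 3 to compound 4 (1.25 log units; beyond the scatter) and is the only step read at this place. A small exchange on that carbonyl carbon is therefore enough to move the dose well beyond the scatter. Nothing shown accounts for the size of this step.

On these data alone, whether the oxygen of methoxy or the size of the group governs the step stays open. An ethyl or an amino group on the same carbonyl carbon would separate these two readings.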